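Swapping the Aryl Group of Compound 1 for Pyridin-2-yl

This account rests on a few compounds, and the source may have more. Where it says the series, first, only, none or still open, it means among the compounds named here.

Compound 1 `CC(C)(C)n1cc2c(n1)C(=O)CC1(CCN(C(=O)c3cc(-c4ccc(F)cc4)nc4ccccc34)CC1)O2` was tested in a functional assay on HepG2 cells (Homo sapiens) for inhibition, read by MTT assay, with a stated time of 72 h (on this read-out lower numbers stand for stronger inhibition and higher numbers for weaker inhibition), where compound 1 gives 2930 nM, the highest of the two numbers recorded so far. Its nearest neighbour, compound 2 `COc1ccc(-c2cc(C(=O)N3CCC4(CC3)CC(=O)c3nn(C(C)(C)C)cc3O4)c3ccccc3n2)cc1`, gives 2780 nM in this assay, and the step of a 1.1-fold lower number from compound 1 to compound 2 (0.02 log units; within the scatter) lies within the scatter. Compound 3 `CC(C)(C)n1cc2c(n1)C(=O)CC1(CCN(C(=O)c3cc(-c4ccccn4)nc4ccccc34)CC1)O2` has not yet been measured. It differs from compound 1 by pyridin-2-yl in place of 4-fluorophenyl on an aromatic carbon. Among the measured compounds shown here, the only measured step, from compound 1 to compound 2, alters a substituent on the same aryl group rather than exchanging the ring itself, so no recorded step bears directly on replacing 4-fluorophenyl with pyridin-2-yl; it shows only that one small change at this position left the number within the scatter. For the measured compounds named here, with no closer precedent, the writer expects no step beyond the scatter in this assay and estimates a 1.0-fold higher number from compound 1 to compound 3 (0.01 log units; within the scatter). Compound 3 is therefore estimated at 3000 nM, with a range from 1200 nM to 8000 nM.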

Compound 3, half-maximal inhibitory concentration: 1500 nM
Estimate against measurement, compound 3: 2.0-fold (0.30 log units) above; the measured number falls inside the stated range.
By their numbers in this assay, from the lowest: compounds 3, 2 and 1 (each within the scatter of the next).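

The aryl group next to the ring nitrogen can be exchanged as a whole ring, not only altered in its substituent: in this assay pyridin-2-yl in place of 4-fluorophenyl gives a 2.0-fold lower number from compound 1 to compound 3 (0.29 log units; within the scatter) and pyridin-2-yl in place of 4-methoxyphenyl gives a 1.9-fold lower number from compound 2 to compound 3 (0.27 log units; within the scatter) with both steps within the scatter. A ring holding a nitrogen and a hydrogen-bond acceptor, which neither earlier aryl group counts, therefore stands at this place with no step beyond the scatter. Nothing among the data given accounts for these numbers.

Going by these compounds, whether an amine or a carboxylic acid on this aryl ring would move the number beyond the scatter stays open. So does whether pyridin-3-yl or pyridin-4-yl would give the same number as pyridin-2-yl at this place.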